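Chain extension on the anilino ring: methyl to pentyl

The source may hold more compounds than are shown below. What is called first, only, known or untested is meant among the compounds shown, and "the series" means these compounds.

Within the data shown here, compound 2 `Cc1ccc(Nc2cccc3c2C(=O)N(C2CCC(=O)NC2=O)C3=O)cc1` holds the higher of the two numbers measured so far in an assay on FRT-Jurkat cells for inhibition of nuclear factor NF-kappa-B complex (Homo sapiens), read by flow cytometry, with a stated time of 24 h, tested at 10 uM; on this read-out lower numbers stand for less inhibition and higher numbers for more inhibition at the one concentration tested (going by the name of the read-out): compound 2 gives 9%. Its nearest neighbour is compound 1 `O=C1CCC(N2C(=O)c3cccc(Nc4ccccc4)c3C2=O)C(=O)N1`, which in this assay gives 4%; the gap between the two lies within the scatter, so no order between them can be claimed. Among the measured compounds shown here, the only measured step in the set, a number 5 percentage points higher from compound 1 to compound 2 (within the scatter), is the one bearing on the present change, since it introduces the methyl that is now extended. Compound 3 `CCCCCc1ccc(Nc2cccc3c2C(=O)N(C2CCC(=O)NC2=O)C3=O)cc1` carries butyl in place of hydrogen on a saturated chain carbon bound to an aromatic carbon. For the measured compounds named here, with the methyl step within the scatter and no other precedent for a longer chain at this place, nothing in the data points to a move beyond the scatter in either direction. The expected step is therefore a number 1 percentage points higher from compound 2 to compound 3 (within the scatter), none beyond the scatter. For compound 3 the estimated value in this assay is 10%, with an expected range from -5% to 25%.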

Compound 3, a percentage reported as inhibition, at one concentration (the size of the read-out at that concentration, not a potency): 23%
Estimate against measurement, compound 3: 13 percentage points below; the measured number falls inside the stated range.
By their numbers in this assay, from the lowest: compounds 1 and 2 (each within the scatter of the next); then compound 3.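

In this assay, among these compounds, methyl to pentyl gives a number 14 percentage points higher from compound 2 to compound 3 (beyond the scatter), the first step to lie beyond the scatter; the methyl step alone, a number 5 percentage points higher from compound 1 to compound 2 (within the scatter), did not show this. Taken from no chain at all to the full pentyl chain, the change gives a number 19 percentage points higher from compound 1 to compound 3 (beyond the scatter), so this position accepts a chain of this length, with the read-out moving towards more inhibition at the one concentration tested. Nothing available explains the rise seen with the pentyl chain.

With only methyl and pentyl at this place, the compounds shown do not tell whether the number climbs steadily with chain length or depends on pentyl specifically. They also leave open whether an octyl chain would go further, and whether a chain ending in an amine or a carboxylic acid would keep the gain.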